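Cytotoxicity of thiophene amines on the bicyclic core

The compounds below may be only part of what the source reports. "The series", "measured", "known", "first", "only" and "open" are said of these compounds alone.

Compound 1 `C[C@H]1[C@H](NCc2ccsc2)C[C@H]2C[C@@H]1C2(C)C`: 50000 nM
Compound 2 `C=Cc1ccsc1CN[C@@H]1C[C@H]2C[C@@H]([C@H]1C)C2(C)C`: 50000 nM
Compound 3 `C[C@H]1[C@H](NCc2sccc2C2CCCCC2)C[C@H]2C[C@@H]1C2(C)C`: 1560 nM

In an ADME assay on MDCK cells (Canis lupus familiaris) for cytotoxicity, read by microscopy, with a stated time of 48 h (on this read-out lower numbers stand for higher toxicity in this test and higher numbers for lower toxicity in this test), compound 1 gives 50000 nM, level at the digits shown with compound 2 and, together with it, the highest of the three numbers. Compound 3 stands furthest from compound 1, with the lower number of the three. Among the measured compounds shown here, the one measured step in this set is a 32-fold lower number from compound 2 to compound 3 (1.51 log units; beyond the scatter), a large change for a single substituent on the aromatic ring.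

Compound 4 `C[C@H]1[C@H](NCc2ccc(Br)s2)C[C@H]2C[C@@H]1C2(C)C` differs from compound 1 by 5-bromothiophen-2-yl in place of thiophen-3-yl on a saturated chain carbon bound to an amine nitrogen. For the measured compounds named here, no measured pair in this set carries a bromine or shifts the attachment of the thiophene, so the only guide is that a substituent on the thiophene of compound 2 moved the number far in compound 3. A bromine is a smaller addition than a cyclohexyl, so a smaller move in the same direction is expected for compound 4, a 2.5-fold lower number from compound 1 to compound 4 (0.40 log units; beyond the scatter). Compound 4 is therefore estimated at 20000 nM, within 5000 nM to 50000 nM.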

Compound 4, minimum cytotoxic concentration: 43000 nM
For compound 4 the middle estimate is 2.2-fold (0.33 log units) below the measured one; measured number inside the range.
By their numbers in this assay, from the lowest: compound 3; then compounds 4, 1 and 2 (each within the scatter of the next).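

In this assay, 5-bromothiophen-2-yl in place of thiophen-3-yl on a saturated chain carbon bound to an amine nitrogen gives a 1.2-fold lower number from compound 1 to compound 4 (0.07 log units; within the scatter) and so leaves the read-out where it stood. Among the compounds shown here, until now the only step measured on the thiophene part was large, so compound 4 adds the first sign that this part of the molecule can also be altered with no change beyond the scatter, even with a bromine added and the attachment of the ring shifted. Nothing available bears on why the read-out holds here.

Since the bromine and the shift in attachment arrive together, the compounds shown leave open what each does alone, which a plain thiophen-2-yl would help to separate. They also leave open how a methyl or a phenyl on the thiophene would read.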